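The source may hold more compounds than are shown below. What is called first, only, known or untested is meant among the compounds shown, and "the series" means these compounds.

Series notes. In a functional assay on SF-268 cells (Homo sapiens) for cytotoxicity, read by sulforhodamine B assay, with a stated time of 48 h, tested at 100 uM (on this read-out higher numbers stand for a weaker effect at the one concentration tested and lower numbers for a stronger effect), compound 1 `COc1cc(-c2cc(/C=C/C(=O)c3ccc(N)cc3)[nH]n2)cc(OC)c1OC` gives -80%. Among the compounds with values here, compound 3 `COc1ccc(-c2cc(/C=C/C(=O)c3ccc(N)cc3)[nH]n2)cc1OC` gives -80%; the step of no change at the digits printed from compound 1 to compound 3 (within the scatter) is the one single-change comparison on hand. Compound 2 `COc1ccc(-c2cc(/C=C/C(=O)c3ccc(OC)c(OC)c3)[nH]n2)cc1` gives -63%, a higher number than compound 1, beyond the scatter, so compound 1 sits with compound 3 at the low end of the three numbers.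

Compound 4 `COc1ccc(C(=O)/C=C/c2cc(-c3cc(OC)c(OC)c(OC)c3)n[nH]2)cc1` differs from compound 1 by methoxy in place of amino on an aromatic carbon. Within the data shown here, no measured step swaps amino for methoxy; the step from compound 1 to compound 3 concerns a different ring and shows no change, and compound 2 carries a methoxy ketone aryl but differs in more than one place. A modest weakening is therefore expected, a number 15 percentage points higher from compound 1 to compound 4 (beyond the scatter), and compound 4 is estimated at -65%, between -85% and -45%.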

Compound 4, a percentage reported as activity, at one concentration (the size of the read-out at that concentration, not a potency): -37%
Compound 4: the middle estimate sits 28 percentage points below what was measured, outside the stated range (above it).
By their numbers in this assay, from the lowest: compounds 1 and 3 (each within the scatter of the next); then compound 2; then compound 4.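

In this assay, replacing 4-aminophenyl with 4-methoxyphenyl gives a number 43 percentage points higher from compound 1 to compound 4 (beyond the scatter) and so marks this place, para to a large group, as sensitive to the change. Within the data shown here, the one earlier single-change step, at a different ring, gave no change at the digits printed from compound 1 to compound 3 (within the scatter) and did not reveal this. No measurement on hand accounts for the size of the new step.

As far as these compounds go, whether a hydroxy or dimethylamino group at this place would stay level with amino remains open. So does whether methoxy in place of amino would give a similar step on the core of compound 3.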